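Dropping a Methyl Group: Expected Effect on Cytotoxicity

A few compounds are considered here, and "the series" means these few. Any claim that something is new, unique, unknown or untested is made for them only; others in the source may bear on it.

Of the compounds shown here, three built on the same core have been measured in a functional assay on Ehrlich cells (Mus musculus) for cytotoxicity, tested at 10 ug/mL; on this read-out higher numbers stand for a stronger effect at the one concentration tested and lower numbers for a weaker effect. Compound 1 `COc1ccccc1C1C(C#N)=C(N)N(c2cc(OC)c(OC)c(OC)c2)C2=C1C(=O)CC(C)(C)C2` gives 30%. Compound 2 `COc1cc(N2C(N)=C(C#N)C(c3ccc([N+](=O)[O-])cc3)C3=C2CC(C)(C)CC3=O)cc(OC)c1OC` gives 10%, and compound 3 `COc1cc(N2C(N)=C(C#N)C(c3ccc(C)cc3)C3=C2CC(C)(C)CC3=O)cc(OC)c1OC` gives 30%. Compound 3 thus stands level with compound 1 at the digits shown, the two together making up the top of the three numbers, with compound 2 furthest away: a number 20 percentage points higher from compound 2 to compound 3 (beyond the scatter). Exchanging one aryl substituent for another, no change at the digits printed from compound 1 to compound 3 (within the scatter), left the read-out unchanged, whereas a number 20 percentage points lower from compound 1 to compound 2 (beyond the scatter) was the only move that shifted it.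

Compound 4 `COc1cc(N2C(N)=C(C#N)C(c3ccccc3)C3=C2CC(C)(C)CC3=O)cc(OC)c1OC` differs from compound 3 only on the aryl ring: hydrogen in place of methyl on an aromatic carbon. Going by the values given here, two measured steps bear on this. The unchanged step from compound 1 to compound 3 shows that two quite different aryl substituents gave the same number, and the step from compound 2 to compound 3 shows that only the nitro group pulled the number down. Removing the methyl is a smaller alteration than either, so no step beyond the scatter is expected in this assay, with at most a slight drift downward. The expected step is a number 3 percentage points lower from compound 3 to compound 4 (within the scatter). Compound 4 is therefore expected to give 27%, with a likely range from 12% to 42%.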

Compound 4, a percentage reported as activity, at one concentration (the size of the read-out at that concentration, not a potency): 0%
The estimate for compound 4 lay 27 percentage points above the measured number; the whole stated range lies above it.
By their numbers in this assay, from the lowest: compounds 4 and 2 (each within the scatter of the next); then compounds 1 and 3 (each within the scatter of the next).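

Going by these compounds alone, the ring on the saturated carbon is less forgiving than the earlier compounds suggested: in this assay losing the single methyl carbon of the 4-methylphenyl group has a clear effect (a number 30 percentage points lower from compound 3 to compound 4 (beyond the scatter)), so the similar numbers for compounds 1 and 3 did not mean that this ring could go without a substituent. The plain phenyl ring also falls short of the 2-methoxyphenyl ring (a number 30 percentage points lower from compound 1 to compound 4 (beyond the scatter)), yet it stays close to the 4-nitrophenyl ring (a number 10 percentage points lower from compound 2 to compound 4 (within the scatter)), so having a substituent here is not enough in itself, and compound 2 goes against any such rule. The data shown offer no measurement that explains why methyl and methoxy keep the read-out while nitro does not.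

On these data alone, it remains open whether other small groups para to a large group, such as ethyl, chlorine or a hydroxyl, would behave like methyl or like nitro. Each number also comes from a single concentration, so it shows only a stronger or weaker effect at that concentration, and a full dose-response series would be needed to show how these compounds compare at other concentrations.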